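The source may report more compounds than this note shows. Statements on the series, on what has been measured and on what is new or still open speak of the compounds shown alone.

In an ADME assay on HFF cells (Homo sapiens) for cytotoxicity, with a stated time of 8 days (on this read-out higher numbers stand for lower toxicity in this test and lower numbers for higher toxicity in this test), three compounds sharing one core have been read. Compound 1 `CNc1nc(N)nc2c1ncn2/C=C1/CC1(CO)CO` gives 265000 nM. Compound 2 `CCCCCOc1nc(N)nc2c1ncn2/C=C1/CC1(CO)CO` gives 259000 nM. With pentyloxy in place of methylamino on an aromatic carbon, the record shows a 1.0-fold lower number from compound 1 to compound 2 (0.01 log units; within the scatter).

Compound 3 `CCCCCCOc1nc(N)nc2c1ncn2/C=C1/CC1(CO)CO` has only a limit, > 200000 nM, and not a number. The data hold (the limit of > 200000 nM in this assay, at which 1 of the 3 values shown sits). Neither step into this compound can be sized: the record gives a step that the limit leaves unreadable from compound 1 to compound 3 and also a step that the limit leaves unreadable from compound 2 to compound 3.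

The next compound to be read is compound 4 `CCCCOc1nc(N)nc2c1ncn2/C=C1/CC1(CO)CO`. It differs from compound 3 by hydrogen in place of ethyl on a saturated chain carbon, four bonds along the chain from an oxygen on an aromatic ring. For the measured compounds named here, no measured step covers this shortening directly, and the two steps that touch compound 3 give no size. Going by the values given here, the only readable guide is the change from methylamino to pentyloxy, a larger exchange at the same aromatic carbon.

Because of a 1.0-fold lower number from compound 1 to compound 2 (0.01 log units; within the scatter) no shift beyond the scatter is expected in this assay, in either direction. The expected step is a step that the limit leaves unreadable from compound 3 to compound 4. For compound 4 the estimated value is 250000 nM, with an expected range from 150000 nM to 400000 nM.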

Compound 4, half-maximal cytotoxic concentration: > 300000 nM
Compound 4: a limit, no number (the forecaster's own chance of this, stated with the estimate: 35%); middle value at least 1.2-fold (0.07 log units) from the limit.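

In this assay compound 4 gives > 300000 nM, which is a limit and not a number, and this is a second alkoxy chain at this aromatic carbon that gives a limit, the first being the hexyloxy of compound 3: the limit of > 300000 nM in this assay, at which 1 of the 4 values shown sits. For the chain itself, shortening pentyloxy to butoxy gives an at least 1.1-fold higher number from compound 2 to compound 4 (0.06 log units; that floor lies within the scatter), while exchanging methylamino for butoxy gives an at least 1.1-fold higher number from compound 1 to compound 4 (0.05 log units; that floor lies within the scatter), so neither change shows a shift beyond the scatter, although a larger true shift in the direction of a higher number is not excluded. The step between the butoxy and hexyloxy compounds cannot be read, since both carry only limits.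

From the compounds shown here alone, how far the true value of compound 4 lies from its limit remains open, as does any dependence on chain length across butoxy, pentyloxy and hexyloxy. Methoxy, a longer chain such as octyloxy, or a carboxylic acid on the chain would show whether this position tolerates change in this test beyond the groups shown here.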